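The source may report more compounds than this note shows. Statements on the series, on what has been measured and on what is new or still open speak of the compounds shown alone.

Series notes. Compound 1 `O=C(O)C12CCC(C(=O)N3CC[C@](c4ccc(C(F)(C(F)(F)F)C(F)(F)F)cc4)(S(=O)(=O)c4ccc(F)cc4)C3)(CC1)C2` carries a carboxylic acid on its bicyclic end; in an ADME assay on microsomes from liver (Homo sapiens) for metabolic stability, with a stated time of 10 min (a higher number here means that more of the compound is left, a lower number that less of the compound is left), compound 1 is recorded as "not determined" (no result reported), so its standing cannot be placed on a number. Compound 2 `O=C1NC(=O)C2(CCC(C(=O)N3CC[C@](c4ccc(C(F)(C(F)(F)F)C(F)(F)F)cc4)(S(=O)(=O)c4ccc(F)cc4)C3)CC2)N1` gives 84%; 93% (2 entries) in this assay, and the several entries of compound 2 in this assay, 84%; 93% (2 entries) shows these repeat entries agree within the usual scatter. Compound 3 `O=C(N1CC[C@](c2ccc(C(F)(C(F)(F)F)C(F)(F)F)cc2)(S(=O)(=O)c2ccc(F)cc2)C1)C1(CO)CCS(=O)(=O)CC1` is the next analogue; it differs from compound 1 by a group of 10 heavy atoms (6 carbon, 3 oxygen, 1 sulfur; one six-membered non-aromatic ring with 1 hetero atom) in place of a group of 10 heavy atoms (8 carbon, 2 oxygen; 2 five-membered non-aromatic rings of carbon only), on a carbonyl carbon. Among the compounds with values here, with no measured step between compounds differing at one place, no direction is assumed for the change into compound 3 beyond the scatter. Compound 3 is expected to give about 75% in this assay, within 45% to 95%.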

Compound 3, percent of the compound remaining: 75%
Beside the measured number, compound 3's estimate shows no gap at the digits printed; the range from low to high includes it.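

No step can be read from compound 1 to compound 3: compound 3 gives 75%, while compound 1 has no single number. Still open, as far as these compounds go, is how the 4-(hydroxymethyl)-1,1-dioxothian-4-yl group compares with the bicyclic end of compound 1 in this assay.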